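Clearance notes: from compound 2 to compound 3

The compounds below may be only part of what the source reports. "The series", "measured", "known", "first", "only" and "open" are said of these compounds alone.

Measured so far:
- compound 1 `O=C(NC1CCCCC1)N1CCN(c2nc(-c3ccc4ccccc4n3)no2)CC1` gives 54 mL/min/kg
- compound 2 `O=C(Nc1ccccc1Cl)N1CCC(c2nc(-c3ccc4ccccc4n3)no2)CC1` gives 11 mL/min/kg

In an in vivo ADME assay on the whole organism for pharmacokinetics, with Rattus norvegicus as the target (on this read-out lower numbers stand for slow clearance and higher numbers for fast clearance), compound 2 stands lowest of the two numbers, with compound 1 higher by more than the scatter. Compound 3 `O=C(NC1CCS(=O)(=O)CC1)N1CCC(c2nc(-c3ccc4ccccc4n3)no2)CC1` has 1,1-dioxothian-4-yl in place of 2-chlorophenyl on an amide-type nitrogen. Within the data shown here, no measured pair shows this change, so the expectation starts from compound 2 at 11 mL/min/kg and stays wide. The expected step of a 1.4-fold higher number from compound 2 to compound 3 (0.13 log units; within the scatter) lies within the scatter, with a slight lean towards faster clearance. The estimate for compound 3 is 15 mL/min/kg with an expected range from 6 mL/min/kg to 36 mL/min/kg for now.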

Compound 3, clearance: 40 mL/min/kg
The estimate for compound 3 lay 2.7-fold (0.43 log units) below the measured number; the measured number lies above the stated range.
By their numbers in this assay, from the lowest: compound 2; then compounds 3 and 1 (each within the scatter of the next).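

In this assay, the group on the amide-type nitrogen matters: 1,1-dioxothian-4-yl in place of 2-chlorophenyl gives a 3.6-fold higher number from compound 2 to compound 3 (0.56 log units; beyond the scatter). Among these compounds, this is the first comparison that differs in one place only, and it leaves 2-chlorophenyl as the group with the slower clearance of this pair. Nothing available explains the step. On these data alone, it remains open whether the step follows the loss of the aromatic ring or the arrival of the ring sulfur and its two oxygens. An oxan-4-yl group on the same nitrogen would help separate these two readings.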